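Chloro to bromo on the urea's aromatic ring: expected activity

The source may report more compounds than this note shows. Statements on the series, on what has been measured and on what is new or still open speak of the compounds shown alone.

Two ureas sharing one core have been measured so far:
compound 1, `Cc1ccccc1NC(=O)N[C@H](C)c1ccccc1`, which gives 99% in an ADME assay on the whole organism with Oryza sativa as the target, tested at 10 uM; a lower number here means a stronger effect, a higher number a weaker effect of the compound at the concentration tested;
compound 2, `C[C@@H](NC(=O)Nc1ccccc1Cl)c1ccccc1`, which gives 93%.

Compound 2 stands at 93%, and compound 1 lies within the scatter of it, as a number 6 percentage points lower from compound 1 to compound 2 (within the scatter) shows. Compound 3, `C[C@@H](NC(=O)Nc1ccccc1Br)c1ccccc1`, differs from compound 2 by bromo in place of chloro on an aromatic carbon. For the measured compounds named here, the only measured step bearing on this also swapped one small group on an aromatic carbon and stayed within the scatter, so in this assay no step beyond the scatter is expected here either; the change from compound 2 to compound 3 is estimated as a number 1 percentage points lower from compound 2 to compound 3 (within the scatter). Compound 3 is therefore expected to give 92%, within 80% to 100%.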

Compound 3, a percentage reported as activity, at one concentration (the size of the read-out at that concentration, not a potency): 94%
Compound 3: the middle estimate sits 2 percentage points below what was measured; the measured number falls inside the stated range.
By their numbers in this assay, from the lowest: compounds 2, 3 and 1 (each within the scatter of the next).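

Bromo in place of chloro gives a number 1 percentage points higher from compound 2 to compound 3 (within the scatter) in this assay and bromo in place of methyl gives a number 5 percentage points lower from compound 1 to compound 3 (within the scatter) on the same aromatic carbon, ortho to a large group. With a third group in this place, methyl, chloro and bromo all remain indistinguishable by this read-out, so the position has so far tolerated each of these swaps without a step beyond the scatter. Nothing is available that would explain this result. On these data alone, whether an amine or a carboxylic acid in this place would give a step beyond the scatter remains open.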